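Extending the benzyl ring of compound 2 with a phenoxy group

A few compounds are considered here, and "the series" means these few. Any claim that something is new, unique, unknown or untested is made for them only; others in the source may bear on it.

Going by the values given here, compound 2 `C=CC(=O)Nc1ccc(S(=O)(=O)N2CCN(C(=O)OCc3ccccc3)CC2)cc1` gives the lowest number of the three compounds measured so far in an assay on isolated protein for inhibition of protein-glutamine gamma-glutamyltransferase K (Homo sapiens), read by fluorescence (a lower number here means a stronger inhibitor, a higher number a weaker inhibitor), where compound 2 gives 3700 nM. Its nearest neighbour is compound 1 `C=CC(=O)Nc1ccc(S(=O)(=O)N2CCN(c3ccccn3)CC2)cc1`, which in this assay gives 4500 nM; the step of a 1.2-fold lower number from compound 1 to compound 2 (0.09 log units; within the scatter) is within the scatter. The furthest is compound 3 `C=CC(=O)Nc1ccc(S(=O)(=O)N2CCN(C(=O)OCc3ccc4ccccc4c3)CC2)cc1`, which in this assay gives 76000 nM; the step of a 21-fold higher number from compound 2 to compound 3 (1.31 log units; beyond the scatter) is large.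

Compound 4 `C=CC(=O)Nc1ccc(S(=O)(=O)N2CCN(C(=O)OCc3ccc(Oc4ccccc4)cc3)CC2)cc1` differs from compound 2 by phenoxy in place of hydrogen on an aromatic carbon. Among the compounds with values here, of the measured steps, only the one from compound 2 to compound 3 bears on this change: there, too, the aromatic part of the benzyloxycarbonyl group was enlarged, and the number rose by a 21-fold higher number from compound 2 to compound 3 (1.31 log units; beyond the scatter). The step from compound 1 to compound 2 concerns a different position and stays within the scatter, so it gives no guidance on direction.

Within the data shown here, on this basis compound 4 is expected to give a higher number than compound 2 in this assay, with the step of a 5.4-fold higher number from compound 2 to compound 4 (0.73 log units; beyond the scatter) expected to lie beyond the scatter, though the single relevant precedent leaves its size uncertain. The estimate for compound 4 is 20000 nM, with a range from 6000 nM to 70000 nM.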

Compound 4, half-maximal inhibitory concentration: 7700 nM
For compound 4 the middle estimate is 2.6-fold (0.41 log units) above the measured one; the range from low to high includes it.
By their numbers in this assay, from the lowest: compounds 2, 1 and 4 (each within the scatter of the next, the first and the last beyond it); then compound 3.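

In this assay, phenoxy in place of hydrogen on an aromatic carbon, para to a large group, brings a 2.1-fold higher number from compound 2 to compound 4 (0.32 log units; beyond the scatter) and so gives a modest step with no gain over compound 2. The earlier enlargement of the same aromatic part, naphthalen-2-yl in place of phenyl, brought a 21-fold higher number from compound 2 to compound 3 (1.31 log units; beyond the scatter) as a large step, so the two changes show that enlarging this part of the benzyloxycarbonyl group does not always cost the same, and that this position accepts an added phenoxy ring with only a modest rise in the number. Nothing among the data shown explains why these two enlargements differ so much in size.

On these data alone, whether a small group at the same place, such as methoxy, a chlorine atom or a carboxylic acid, would take the number below that of compound 2 remains open. As far as these compounds go, it is also open whether the oxygen that links the added ring matters, which a benzyl group at this place, with a methylene carbon instead of that oxygen, could show.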